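The compounds below may be only part of what the source reports. "The series", "measured", "known", "first", "only" and "open" are said of these compounds alone.

Of the compounds shown here, three of a shared design have been tested in an assay on isolated protein for inhibition of Dihydrofolate reductase (Homo sapiens); a lower number here means a stronger inhibitor, a higher number a weaker inhibitor. They differ only in the fused two-ring head group attached through a methylene link to the rest of the molecule. Compound 1, `NCCCC(NC(=O)c1ccc(NCc2cnc3nc(N)nc(O)c3c2)cc1)C(=O)O`, gives 8500 nM. Compound 2, `NCCCC(NC(=O)c1ccc(NCc2ccc3nc(N)nc(O)c3c2)cc1)C(=O)O`, gives 750 nM. Compound 3, `NCCCC(NC(=O)c1ccc(NCc2ccc3nc(N)nc(N)c3n2)cc1)C(=O)O`, gives 16 nM. Among these numbers compound 2 stands second highest: its value lies well above that of compound 3 and well below that of compound 1, both gaps beyond the usual scatter.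

Compound 4, `NCCCC(NC(=O)c1ccc(NCc2ccc3nc(N)nc(N)c3c2)cc1)C(=O)O`, has not been measured. It is built from compound 2 by one change: amino in place of hydroxy on an aromatic carbon. Within the data shown here, no pair of measured compounds differs by this change alone, so its size cannot be read directly. Among the measured compounds shown here, the only guide is compound 3, which also carries an amino group at that part of the fused ring and gives 16 nM, far below compound 2, although compound 3 also differs from compound 2 in the ring itself.

On that basis the step from compound 2 to compound 4 is expected to be a large fall in the number, estimated as a 38-fold lower number from compound 2 to compound 4 (1.57 log units; beyond the scatter). Compound 4 is therefore expected to give about 20 nM, with a likely range from 5 nM to 80 nM.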

Compound 4, half-maximal inhibitory concentration: 35 nM
For compound 4 the middle estimate is 1.8-fold (0.24 log units) below the measured one; low and high end bracket the measured number.
By their numbers in this assay, from the lowest: compound 3; then compound 4; then compound 2; then compound 1.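

In this assay, a 21-fold lower number from compound 2 to compound 4 (1.33 log units; beyond the scatter) gives a direct reading of this exchange. Amino replaces hydroxy with nothing else in the molecule altered. The two groups match in everything counted here: each is a single heavy atom with one hydrogen-bond donor, one hydrogen-bond acceptor and no net charge. Those counts therefore do not foretell the step, and swapping one oxygen for one nitrogen on this aromatic carbon, next to the ring nitrogen, is enough to move the number this far, although no measurement shown here explains the size of the change.

From the compounds shown here alone, whether other groups in this place, such as a methoxy group, a methylamino group or a plain hydrogen, would hold the number near that of compound 4 remains open. Also open, going by these compounds, is whether the same exchange of hydroxy for amino on the core of compound 1 would bring a step of similar size, or whether this large effect belongs to the core shared by compound 2 and compound 4 alone.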